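Pyridine-linked biaryl analogues: projecting a hydroxyphenyl swap

The source may hold more compounds than are shown below. What is called first, only, known or untested is meant among the compounds shown, and "the series" means these compounds.

Measured in a functional assay on HOS cells (Homo sapiens) for inhibition, with a stated time of 72 h; a higher number here means a weaker inhibitor, a lower number a stronger inhibitor:
compound 1 `NC1CCC(Nc2nc(NCc3ccc(-c4ccsc4)cc3)c3ncn(C4CCCC4)c3n2)CC1` gives 120 nM
compound 2 `NC1CCC(Nc2nc(NCc3ccc(-c4ccsc4)nc3)c3ncn(C4CCCC4)c3n2)CC1` gives 89 nM
compound 3 `NC1CCC(Nc2nc(NCc3ccc(-c4ccccc4O)cc3)c3ncn(C4CCCC4)c3n2)CC1` gives 1160 nM

Compounds 1 and 2 share one core and differ by 6-(thiophen-3-yl)pyridin-3-yl in place of 4-(thiophen-3-yl)phenyl on a saturated chain carbon bound to a nitrogen on an aromatic ring; the step of a 1.3-fold lower number from compound 1 to compound 2 (0.13 log units; within the scatter) lies within the scatter. From compound 1 to compound 3 the change is 2-hydroxyphenyl in place of thiophen-3-yl on an aromatic carbon, and the step of a 9.7-fold higher number from compound 1 to compound 3 (0.99 log units; beyond the scatter) is a modest loss. Compound 4 `NC1CCC(Nc2nc(NCc3ccc(-c4ccccc4O)nc3)c3ncn(C4CCCC4)c3n2)CC1` carries the same kind of change on the core of compound 2, namely (2-hydroxyphenyl in place of thiophen-3-yl on an aromatic carbon); here the place is next to the ring nitrogen, whereas in compound 3 the ring is of carbon only. Because the step of a 9.7-fold higher number from compound 1 to compound 3 (0.99 log units; beyond the scatter) was modest and the step of a 1.3-fold lower number from compound 1 to compound 2 (0.13 log units; within the scatter) was within the scatter, a step of similar size is expected: a 9.6-fold higher number from compound 2 to compound 4 (0.98 log units; beyond the scatter). Compound 4 is therefore estimated at 850 nM in this assay, most likely between 350 nM and 2000 nM.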

Compound 4, half-maximal inhibitory concentration: 14 nM
Compound 4: middle estimate off by 61-fold (1.78 log units), on the high side; measured number outside the range, below it.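

In this assay, 2-hydroxyphenyl in place of thiophen-3-yl on the core of compound 2 gives a 6.4-fold lower number from compound 2 to compound 4 (0.80 log units; beyond the scatter). The change therefore does not carry over between these two cores with the same outcome, and its direction reverses: the same change on two cores in this assay, a 9.7-fold higher number (0.99 log units; beyond the scatter) from compound 1 to compound 3 and a 6.4-fold lower number (0.80 log units; beyond the scatter) from compound 2 to compound 4, 61-fold (1.79 log units) apart, beyond the scatter of two such steps The result shows that, in this pair of cores, the effect of the swap differs between a place next to the ring nitrogen and a ring of carbon only, but it does not show why, nor whether this holds for any other group.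

The compounds shown leave open how an unsubstituted phenyl group would behave on either core. As far as these compounds go, it also remains open whether a 2-aminophenyl or 2-methoxyphenyl group would follow 2-hydroxyphenyl.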